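Thiosemicarbazone series on the quinoline aldehyde core: aryl variation

The compounds below may be only part of what the source reports. "The series", "measured", "known", "first", "only" and "open" are said of these compounds alone.

For the measured compounds named here, compound 1 `S=C(N/N=C/c1ccc2ccccc2n1)Nc1ccc(Br)cc1` is the weaker of the two measured members. In a functional assay on SGC-7901 cells (Homo sapiens) for antiproliferative activity, read by sulforhodamine B assay, with a stated time of 72 h (on this read-out lower numbers stand for stronger inhibition and higher numbers for weaker inhibition), compound 1 gives 69400 nM, the highest number of the pair. Going by the values given here, compound 2 `CN(C)C(=S)N/N=C/c1ccc2ccccc2n1`, which carries a dimethylamino group in place of the aryl amine on the thiourea, gives 30 nM in this assay, a far lower number and well beyond the scatter; no single-point step connects the two, so the comparison rests on the two values alone. Compound 3 `COc1ccccc1NC(=S)N/N=C/c1ccc2ccccc2n1` differs from compound 1 in one place: 2-methoxyphenyl in place of 4-bromophenyl on an amide-type nitrogen. Among the compounds with values here, with no measured step of this kind available, the expectation is a modest move toward a lower number in this assay, since compound 1 stands at 69400 nM and leaves room for improvement, though a change within the scatter cannot be excluded. The expected step is a 3.5-fold lower number from compound 1 to compound 3 (0.54 log units; beyond the scatter). Compound 3 is estimated at 20000 nM, within a range from 3000 nM to 100000 nM.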

Compound 3, half-maximal inhibitory concentration: > 100000 nM
Compound 3 ended at the assay's limit; the forecaster's own chance of this, stated with the estimate: 10%; middle value at least 5.0-fold (0.69 log units) from the limit.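

The position on the amide-type nitrogen now has its first one-place comparison. In this assay compound 3 gives > 100000 nM, a limit of the assay and not a number: the limit of > 100000 nM in this assay, at which 1 of the 3 values shown sits.

With 2-methoxyphenyl in place of 4-bromophenyl, the series shows an at least 1.4-fold higher number from compound 1 to compound 3 (0.15 log units; that floor lies within the scatter), so this change brings no lower number, and how far the true step reaches cannot be read from a limit. The floor alone does not separate the two aryl groups beyond the scatter.

Open, as far as these compounds go, is how a 4-methoxyphenyl or an unsubstituted phenyl group would read on this nitrogen, since the pair changes both the substituent and its place on the ring. Also open, from the compounds shown here alone, is whether a single methyl group or a morpholine ring there would read differently from either aryl group.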